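The compounds below may be only part of what the source reports. "The series", "measured", "known", "first", "only" and "open" are said of these compounds alone.

Compound 2 `CC#CC(CC(=O)O)c1ccc(OCc2ccn3cc(-c4ccccc4)nc3c2)cc1` sits highest of the three numbers measured in an assay on isolated protein for agonist activity at Free fatty acid receptor 1 (Homo sapiens) (a lower number here means that less compound is needed, a higher number that more compound is needed for the effect), where compound 2 gives 1260 nM. Compound 3 `CC#CC(CC(=O)O)c1ccc(OCc2ccc3nc(-c4ccc(F)cc4F)cn3c2)cc1` is nearest to it, and compound 3 gives 825 nM; compound 1 `CC#CC(CC(=O)O)c1ccc(OCc2ccc3nc(-c4ccc(C(F)(F)F)cc4)cn3c2)cc1` is furthest, and compound 1 gives 558 nM. Among the compounds with values here, the only single-point step among them, a 1.5-fold higher number from compound 1 to compound 3 (0.17 log units; within the scatter), concerns the aryl group on a different core and stays within the scatter. Compound 4 `CC#CC(CC(=O)O)c1ccc(OCc2ccn3cc(-c4ccccc4C)nc3c2)cc1` differs from compound 2 by methyl in place of hydrogen on an aromatic carbon. Within the data shown here, no measured step tests a methyl on this ring, so the change from compound 2 to compound 4 is expected to give no step beyond the scatter, a 1.1-fold lower number from compound 2 to compound 4 (0.06 log units; within the scatter). For compound 4 the estimate in this assay is 1100 nM, between 450 nM and 2700 nM.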

Compound 4, half-maximal effective concentration: 459 nM
For compound 4 the middle estimate is 2.4-fold (0.38 log units) above the measured one, within the range that was stated.
By their numbers in this assay, from the lowest: compounds 4, 1, 3 and 2 (each within the scatter of the next, the first and the last beyond it).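

In this assay, the change from phenyl to 2-methylphenyl gives a 2.7-fold lower number from compound 2 to compound 4 (0.44 log units; beyond the scatter), the only step shown that lies beyond the scatter. Within the data shown here, a single methyl on an aromatic carbon, ortho to a large group, can therefore shift the number on this core, which the one earlier step, made on a different core, could not show. Nothing available explains this shift.

As far as these compounds go, whether a chlorine or a methoxy group at this place would act like the methyl remains open, as does whether the methyl would have the same effect on the core of compound 1.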